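This account rests on a few compounds, and the source may have more. Where it says the series, first, only, none or still open, it means among the compounds named here.

Compound 3 `Cc1cccc(-c2onc3ccc(C(=O)O)cc23)c1` stands second highest of the three numbers recorded so far in an assay for inhibition of inositol hexakisphosphate kinase 3 (Homo sapiens), read by colorimetric assay, coupled enzyme assay and malachite green, with a stated time of 120 min, in the presence of a further agent that is not named here; on this read-out higher numbers stand for weaker inhibition and lower numbers for stronger inhibition; in that assay compound 3 gives 1410 nM. Its nearest neighbour is compound 1 `Cc1cccc(-c2onc3ccc(/C=C/C(=O)O)cc23)c1`, which in this assay gives 3590 nM, and its furthest is compound 2 `CC(C)C(=O)Nc1ccc(-c2onc3ccc(C(=O)O)cc23)cc1`, which in this assay gives 210 nM. For the measured compounds named here, the only single-point step measured so far, a 2.5-fold lower number from compound 1 to compound 3 (0.41 log units; beyond the scatter), concerns the acid end of the shared core and lies beyond the scatter.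

Compound 4 `O=C(O)c1ccc2noc(-c3cccc(Oc4ncc(Cl)cc4Cl)c3)c2c1` arises from compound 3 by the change ((3,5-dichloropyridin-2-yl)oxy in place of methyl on an aromatic carbon). Going by the values given here, no measured step alters this position of the shared core, so the recorded step from compound 1 to compound 3 has no direct bearing on it; it shows only that the core tolerates a change of the acid with a modest shift. Compound 2 differs from compound 3 in more than one place, so its lower number cannot be assigned to any single change. Among the compounds with values here, with no step at the site of the new group, the expectation for compound 4 rests on little: compound 4 is estimated to give 600 nM in this assay, between 150 nM and 2500 nM, which would mean an expected step of a 2.4-fold lower number from compound 3 to compound 4 (0.37 log units; beyond the scatter).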

Compound 4, half-maximal inhibitory concentration: 3090 nM
Compound 4: the middle estimate sits 5.2-fold (0.71 log units) below what was measured; the whole stated range lies below it.
By their numbers in this assay, from the lowest: compound 2; then compound 3; then compounds 4 and 1 (each within the scatter of the next).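

In this assay, the aromatic carbon that carries methyl in compound 3, meta to a large group, now has a measured step of its own: placing (3,5-dichloropyridin-2-yl)oxy there gives a 2.2-fold higher number from compound 3 to compound 4 (0.34 log units; beyond the scatter). The position therefore accepts a far larger substituent, with 9 heavy atoms entering where 1 leaves, and inhibition is weakened only modestly, though beyond the scatter, rather than lost; the earlier step, which concerned the acid end of the shared core, could not show this. Nothing in the data at hand explains the direction or size of this shift.

For the compounds shown here, the single step changes the oxygen link, the aromatic ring, its nitrogen and the two chlorines together, so it remains open which of these parts accounts for the higher number, and whether a simple phenoxy, a methoxy or an unchlorinated pyridin-2-yloxy group at this carbon would give a different result. Going by these compounds, it is also open whether an amine or a hydroxy group here would move the number the other way, and whether the same replacement would give a similar step with the 2-carboxyethenyl group of compound 1 in place of the carboxy group.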